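The compounds below may be only part of what the source reports. "The series", "measured", "known", "first", "only" and "open" are said of these compounds alone.

In a functional assay on A549 cells (Homo sapiens) for inhibition, read by sulforhodamine B assay, with a stated time of 72 h (a higher number here means a weaker inhibitor of growth, a lower number a stronger inhibitor of growth), compound 1 `CCOC(=O)/C=C/c1ccncc1-c1ccc2cc[nH]c2c1` gives 5740 nM as a measured number. Compound 2 `O=C(CCc1ccncc1-c1ccc2ccccc2c1)N1CCOCC1` reads > 10000 nM in that test, which is a limit of the assay and not a number. Compound 3 `O=C(O)CCc1ccncc1-c1ccc2ccccc2c1` differs from compound 2 in one place, with hydroxy in place of morpholin-4-yl on a carbonyl carbon, so (morpholin-4-yl)carbonyl becomes carboxy. Going by the values given here, with no measured step to go on, the change expected in this assay is small and without clear direction, an estimated step that the limit leaves unreadable from compound 2 to compound 3 and nothing beyond the scatter. The expected value for compound 3 is 12000 nM (range 5000 nM to 30000 nM).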

Compound 3, concentration for 50% growth inhibition: > 10000 nM
Compound 3: a limit, no number (the forecaster's own chance of this, stated with the estimate: 65%); the middle value is on the limit's open side.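

Compound 2 and compound 3 each give a limit and not a number, so no step can be read between them: the limit of > 10000 nM in this assay, at which 2 of the 3 values shown sit. From the compounds shown here alone, whether hydroxy in place of morpholin-4-yl on a carbonyl carbon changes growth inhibition at all stays open.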